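Fluorine on the phenyl ring of a triterpenoid triazole ester

The compounds below may be only part of what the source reports. "The series", "measured", "known", "first", "only" and "open" are said of these compounds alone.

Measured so far in a functional assay on DU-145 cells (Homo sapiens) for antiproliferative activity, read by MTT assay, with a stated time of 48 h; on this read-out lower numbers stand for stronger inhibition and higher numbers for weaker inhibition:
- compound 1, `C/C(=C\CC/C(C)=C/CC[C@@H]1[C@@]2(C)CCC(=O)C(C)(C)[C@H]2CC[C@@]1(C)O)CC/C=C(\C)C(=O)OCc1cn(-c2ccccc2)nn1`: 95500 nM
- compound 2, `C/C(=C\CC/C(C)=C/CC[C@@H]1[C@@]2(C)CCC(=O)C(C)(C)[C@H]2CC[C@@]1(C)O)CC/C=C(\C)C(=O)OCc1cn(C[C@@H]2O[C@H](n3ccc(=O)[nH]c3=O)[C@H]3OC(C)(C)O[C@H]32)nn1`: > 150000 nM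
- compound 3, `COc1cccc(-n2cc(COC(=O)/C(C)=C/CC/C(C)=C/CC/C(C)=C/CC[C@@H]3[C@@]4(C)CCC(=O)C(C)(C)[C@H]4CC[C@@]3(C)O)nn2)c1`: > 150000 nM

Within the data shown here, compound 1 gives 95500 nM in this assay, the only actual number among the three values. For compound 2 this assay reports only a limit, > 150000 nM. For compound 3 it likewise reports only a limit, > 150000 nM, so two of the three compounds sit at the limit of > 150000 nM in this assay, at which 2 of the 3 values shown sit.

Among the measured compounds shown here, the one measured step that changes a single place is an at least 1.5-fold higher number from compound 1 to compound 3 (0.19 log units; that floor lies within the scatter). Going by these compounds, that step therefore gives no firm direction: the floor of the change lies within the scatter, and the true size is unknown because compound 3 is a limit.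

Compound 4, `C/C(=C\CC/C(C)=C/CC[C@@H]1[C@@]2(C)CCC(=O)C(C)(C)[C@H]2CC[C@@]1(C)O)CC/C=C(\C)C(=O)OCc1cn(-c2ccc(F)cc2)nn1`, differs from compound 1 by fluoro in place of hydrogen on an aromatic carbon. This is a smaller group than the methoxy of compound 3, entering at the same kind of place. For the measured compounds named here, with only one bearing step, and that step uncertain, no shift beyond the scatter is expected; the estimated step is a 1.2-fold higher number from compound 1 to compound 4 (0.06 log units; within the scatter). Compound 4 is therefore expected to give about 110000 nM in this assay, with a range from 55000 nM to 220000 nM.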

Compound 4, half-maximal inhibitory concentration: > 150000 nM
Compound 4 ended at the assay's limit; the forecaster's own chance of this, stated with the estimate: 30%; middle value at least 1.3-fold (0.13 log units) from the limit.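

In this assay, fluoro in place of hydrogen on the phenyl ring is an at least 1.5-fold higher number from compound 1 to compound 4 (0.19 log units; that floor lies within the scatter), so even this change of a single atom gives no firm direction at this position. Among these compounds, for compound 4 the assay reports > 150000 nM, which is a limit and not a number, and the steps that join two such limits, including the one from compound 3 to compound 4, cannot be read. What is new is that compound 4 joins compound 3 at the limit, so compound 1, with its unsubstituted phenyl, is the only one of the phenyl compounds with an actual number, though the floor of each step stays within the scatter: the limit of > 150000 nM in this assay, at which 3 of the 4 values shown sit.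

Going by these compounds, how far compound 3 and compound 4 truly lie from compound 1 stays open, and so does whether any change on this ring can lower the number at all. Whether an amine or a carboxylic acid in place of the fluoro would give a measurable value, and on which side of compound 1 it would fall, is not answered by the compounds shown.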